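Halogenated bicyclic variation on a dibenzyloxy lactone series

The source may hold more compounds than are shown below. What is called first, only, known or untested is meant among the compounds shown, and "the series" means these compounds.

Compound 1 `O=C1O/C(=C\Cn2cnc3cncc(Br)c32)C(OCc2ccccc2)=C1OCc1ccccc1`, compound 2 `O=C1NC(O)(CCn2cnc3cncc(Br)c32)C(OCc2ccccc2)=C1OCc1ccccc1` and compound 3 `O=C1NC(O)(CCn2cnc3ccnc(Cl)c32)C(OCc2ccccc2)=C1OCc1ccccc1` have been measured in a functional assay on HeLa cells (Homo sapiens) for antiproliferative activity, read by MTT assay, with a stated time of 72 h; on this read-out lower numbers stand for stronger inhibition and higher numbers for weaker inhibition. Compound 1 gives 15000 nM in this assay. Compound 2 gives 77000 nM in this assay, and compound 3 gives 21000 nM in this assay. The difference between the core of compound 1 and the core of compound 2 is not broken down here. Between compound 2 and compound 3 the change is a group of 10 heavy atoms (6 carbon, 3 nitrogen, 1 chlorine; one five-membered aromatic ring with 2 hetero atoms, one six-membered aromatic ring with 1 hetero atom) in place of a group of 10 heavy atoms (6 carbon, 3 nitrogen, 1 bromine; one five-membered aromatic ring with 2 hetero atoms, one six-membered aromatic ring with 1 hetero atom), on a saturated chain carbon, two bonds along the chain from a saturated ring carbon; it made a 3.7-fold lower number from compound 2 to compound 3 (0.56 log units; beyond the scatter).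

Compound 4 `O=C1O/C(=C\Cn2cnc3ccnc(Cl)c32)C(OCc2ccccc2)=C1OCc1ccccc1` is not yet measured in this assay. It differs from compound 1 by a group of 10 heavy atoms (6 carbon, 3 nitrogen, 1 chlorine; one five-membered aromatic ring with 2 hetero atoms, one six-membered aromatic ring with 1 hetero atom) in place of a group of 10 heavy atoms (6 carbon, 3 nitrogen, 1 bromine; one five-membered aromatic ring with 2 hetero atoms, one six-membered aromatic ring with 1 hetero atom), on a saturated chain carbon bound to a double-bonded chain carbon. This is the same kind of change as from compound 2 to compound 3, but its place differs: in compound 4 it sits on a saturated chain carbon bound to a double-bonded chain carbon, whereas in compound 3 it sits on a saturated chain carbon, two bonds along the chain from a saturated ring carbon. Resting on a 3.7-fold lower number from compound 2 to compound 3 (0.56 log units; beyond the scatter), compound 4 is expected to show a 2.5-fold lower number from compound 1 to compound 4 (0.40 log units; beyond the scatter) in this assay. With a single prior example and a different place, the expectation is held loosely. Compound 4 is estimated at 6000 nM in this assay, between 2000 nM and 20000 nM.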

Compound 4, half-maximal inhibitory concentration: > 100000 nM
Compound 4 gave a limit, no number; the forecaster's own chance of this, stated with the estimate: 5%; middle value at least 16-fold (1.22 log units) away from the limit.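

Compound 4 in this assay gives a limit of the assay and not a number: the limit of > 100000 nM in this assay, at which 1 of the 4 values shown sits.

With the chlorine-bearing group in place of the bromine-bearing group on the core of compound 1, the result is an at least 6.6-fold higher number from compound 1 to compound 4 (0.82 log units; beyond the scatter), so on these two cores the change does not carry over with the same direction: the same change on two cores in this assay, a 3.7-fold lower number (0.56 log units; beyond the scatter) from compound 2 to compound 3 and an at least 6.6-fold higher number (0.82 log units; beyond the scatter) from compound 1 to compound 4, at least 24-fold (1.38 log units) apart, beyond the scatter of two such steps

These two pairs do not show what sets the cores apart, do not separate the halogen from the rest of the group, and, with a limit at one end, leave the true size of the step on the core of compound 1 unknown.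

Open, going by these compounds, is whether either direction would hold on a third core, and whether a fluorine or a methyl in place of the halogen would follow the same course on each core. Also open, on these data alone, is how a longer chain to the halogen-bearing group, or a free hydroxyl in place of either benzyloxy group, would read on each core.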